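The source may report more compounds than this note shows. Statements on the series, on what has been measured and on what is new or still open speak of the compounds shown alone.

Measured so far in a functional assay on HepG2 cells (Homo sapiens) for inhibition, read by MTT assay, with a stated time of 72 h; a lower number here means a stronger inhibitor, a higher number a weaker inhibitor:

- Compound 1 `C#CCSc1nc(Nc2ccc(F)cc2)c2ccncc2n1`: 10800 nM
- Compound 2 `C#CCSc1nc(Nc2ccc([N+](=O)[O-])cc2)c2ccncc2n1`: > 80000 nM (a limit)
- Compound 3 `C#CCSc1nc(Nc2ccc(OC)cc2)c2ccncc2n1`: > 80000 nM (a limit)

Compound 1 is the only one of the three with an actual number, which makes it the sole reference point. Compound 2 and compound 3 both stop at the limit of > 80000 nM in this assay, at which 2 of the 3 values shown sit. Replacing the fluoro group on an aromatic carbon with nitro gives an at least 7.4-fold higher number from compound 1 to compound 2 (0.86 log units; beyond the scatter). Replacing it with methoxy gives an at least 7.4-fold higher number from compound 1 to compound 3 (0.86 log units; beyond the scatter). Each of these sizes is a minimum, so the real steps may be larger. The remaining comparison is a step that the two limits leave unreadable from compound 2 to compound 3, so it cannot rank those two compounds.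

Compound 4 `C#CCSc1nc(Nc2cccc(O)c2)c2ccncc2n1` has not yet been measured. Its change from compound 1 is 3-hydroxyphenyl in place of 4-fluorophenyl on a nitrogen on an aromatic ring. The 4-fluorophenyl group leaves, so the fluoro group is lost, as it was in both measured steps. However, neither of those steps tested a 3-hydroxyphenyl group, so they are only a loose guide. Since both went towards a weaker inhibitor, a move in the same direction, beyond the scatter, is expected here, though the size is uncertain. The expected change is a 2.8-fold higher number from compound 1 to compound 4 (0.44 log units; beyond the scatter). Compound 4 is estimated at 30000 nM, with an expected range of 8000 nM to 80000 nM.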

Compound 4, half-maximal inhibitory concentration: 29500 nM
Beside the measured number, compound 4's estimate is 1.0-fold (0.01 log units) above it, within the range that was stated.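

In this assay, the change to 3-hydroxyphenyl gives a 2.7-fold higher number from compound 1 to compound 4 (0.44 log units; beyond the scatter), the first step away from 4-fluorophenyl whose size is an actual measurement and not just a minimum. Replacing the 4-fluorophenyl group therefore does not always carry a compound to the end of the measurable range: compound 4 keeps an actual number, whereas compound 2 and compound 3 each stop at a limit: the limit of > 80000 nM in this assay, at which 2 of the 4 values shown sit. The entering group carries 1 hydrogen-bond donor and 1 hydrogen-bond acceptor where the leaving group carries 0, and with that swap compound 4 is still a weaker inhibitor than compound 1.

This single step changes both the substituent and its place on the ring, so it cannot say whether the loss of fluoro, the arrival of hydroxy or the new location accounts for the shift. A plain phenyl, 3-fluorophenyl or 4-hydroxyphenyl group would help to separate these effects, while an amine or a carboxylic acid on the same ring remains an open question.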